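The compounds below may be only part of what the source reports. "The series", "measured", "known", "first", "only" and "open" are said of these compounds alone.

Measured so far:
compound 1 `Cc1nc(-c2ccc(C(F)(F)F)cc2)sc1CNc1ccc(CCC(=O)O)cc1` – 67.6 nM
compound 2 `CC(CC(=O)O)c1ccc(NCc2cccc(Oc3ccccc3)c2)cc1` – 126 nM
compound 3 `CNC(=O)CCc1ccc(NCc2cccc(Oc3ccccc3)c2)cc1` – 49 nM

In a functional assay on CHO cells for agonist activity at Free fatty acid receptor 1 (Homo sapiens) (a higher number here means that more compound is needed for the effect, a lower number that less compound is needed), compound 1 gives 67.6 nM, the second highest of the three numbers. Its nearest neighbour is compound 3, which gives 49 nM, and the furthest is compound 2 with 126 nM; both gaps to compound 1 lie within the scatter, so no order among the three can be stated.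

Compound 4 `Cc1nc(-c2ccc(C(F)(F)F)cc2)sc1CNc1ccc([C@H]2C[C@@H]2C(=O)NC2CCNC2)cc1` differs from compound 1 in one place: 2-((pyrrolidin-3-yl)carbamoyl)cyclopropyl in place of 2-carboxyethyl on an aromatic carbon. For the measured compounds named here, the only measured step that bears on this is a 2.6-fold lower number from compound 2 to compound 3 (0.41 log units; beyond the scatter), where a carbamoyl group took the place of a carboxy-bearing chain on the same aromatic carbon and the number moved modestly down. Going by the values given here, the change from compound 1 to compound 4 is of the same kind but larger, as the group entering carries two rings and two hydrogen-bond donors, and no measured pair covers such a group. On the basis of the step from compound 2 to compound 3 alone, a modest downward step in this assay is expected for compound 4, with wide uncertainty, giving a 1.7-fold lower number from compound 1 to compound 4 (0.23 log units; within the scatter). The estimate for compound 4 in this assay is 40 nM, within 8 nM to 250 nM.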

Compound 4, half-maximal effective concentration: 204 nM
Estimate against measurement, compound 4: 5.1-fold (0.71 log units) below; the measured number falls inside the stated range.
By their numbers in this assay, from the lowest: compounds 3, 1, 2 and 4 (each within the scatter of the next, the first and the last beyond it).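

In this assay, replacing 2-carboxyethyl with 2-((pyrrolidin-3-yl)carbamoyl)cyclopropyl gives a 3.0-fold higher number from compound 1 to compound 4 (0.48 log units; beyond the scatter), so on this aromatic carbon, para to a large group, a carbamoyl-bearing group can move the number up as well as down, the opposite direction to a 2.6-fold lower number from compound 2 to compound 3 (0.41 log units; beyond the scatter). The two steps differ in the entering group and in the rest of the molecule, so a carbamoyl group alone does not set the direction of change at this position, and the modest size of the new step shows that agonist activity survives this much larger group without a carboxylic acid. No data at hand account for the rise.

The compounds shown leave open how the cyclopropane ring, the pyrrolidine and the loss of the carboxylic acid each contribute to the step. The core of compound 1 carrying 2-carboxycyclopropyl or 2-(methylcarbamoyl)ethyl would separate these parts, and the opposite stereoisomer of the cyclopropane would test the role of the two defined stereocentres.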